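The source may hold more compounds than are shown below. What is called first, only, known or untested is meant among the compounds shown, and "the series" means these compounds.

The measured compounds and their values:

- compound 1, `CCCCc1nc(=O)c(S(=O)(=O)c2ccc(-c3ccc(F)cc3)cc2)c(O)n1-c1c(OC)cccc1OC`: 100%
- compound 2, `CCCCc1[nH]c(=O)c(S(=O)(=O)c2ccc(-c3ccncc3C)cc2)c(O)c1-c1c(OC)cccc1OC`: 80%
- compound 3, `CCCCc1[nH]c(=O)c(S(=O)(=O)c2ccc(-n3ccccc3=O)cc2)c(O)c1-c1c(OC)cccc1OC`: 100%

All three were tested in an ADME assay on microsomes from liver (Homo sapiens) for metabolic stability, using NADPH, with a stated time of 10 min; on this read-out higher numbers stand for a more stable compound and lower numbers for a less stable compound. Compound 1 gives 100%, level with compound 3 at the digits shown, and together these are the highest of the three numbers; compound 2 lies lower, a gap beyond the scatter. Compound 4, `CCCCc1nc(=O)c(S(=O)(=O)c2ccccc2)c(O)n1-c1c(OC)cccc1OC`, has not yet been measured in this assay. It differs from compound 1 by hydrogen in place of 4-fluorophenyl on an aromatic carbon.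

Among the compounds with values here, only one single-place step among the measured compounds has been recorded: a number 20 percentage points higher from compound 2 to compound 3 (beyond the scatter). That step swaps one ring for another on an aromatic carbon, whereas the change to compound 4 removes the ring altogether, so the comparison is loose. Compound 1 already sits at the top of the scale, so any step can only go down or stay level. Within the data shown here, with no measured example of removing this ring, the expectation is a step that stays within the scatter, or at most a modest fall.

Compound 4 is therefore estimated at 90%, with a range from 70% to 100%. This estimate means an expected step of a number 10 percentage points lower from compound 1 to compound 4 (within the scatter).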

Compound 4, percent of the compound remaining: 89%
Beside the measured number, compound 4's estimate is 1 percentage points above it, within the range that was stated.
By their numbers in this assay, from the lowest: compounds 2 and 4 (each within the scatter of the next); then compounds 1 and 3 (each within the scatter of the next).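

In this assay, putting hydrogen in place of 4-fluorophenyl gives a number 11 percentage points lower from compound 1 to compound 4 (beyond the scatter), a modest step. The earlier step, a number 20 percentage points higher from compound 2 to compound 3 (beyond the scatter), only swapped one ring for another on an aromatic carbon, whereas this result shows what happens when the ring on this carbon, para to a large group, is taken away altogether: the number falls, yet compound 4 still gives 89%, so a high reading here does not depend entirely on having this ring in place. Nothing available explains why the number moves with this change.

The change removes the ring and its fluorine together, so these compounds cannot show whether the step comes from the ring or from the fluorine, and a plain phenyl group on the same carbon would help to separate the two. How groups of a different kind, such as a small amine, a carboxylic acid or a short alkyl chain, would read on this carbon also remains open, as does whether the same step would appear on another core among these compounds.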